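From an inactive dichlorophenyl compound to its isomer

The compounds below may be only part of what the source reports. "The series", "measured", "known", "first", "only" and "open" are said of these compounds alone.

In a functional assay on PC-3 cells (Homo sapiens) for antiproliferative activity, read by MTT assay, with a stated time of 72 h (a lower number here means a stronger inhibitor, a higher number a weaker inhibitor), compound 1 (`O=C(N/N=C/c1ccc(F)cc1)Nc1ccc(Oc2ccnc3[nH]ccc23)c(F)c1`) gives 2330 nM and compound 2 (`N#Cc1ccc(/C=N/NC(=O)Nc2ccc(Oc3ccnc4[nH]ccc34)c(F)c2)cc1`) gives 9030 nM on the same read-out. Going by the values given here, compound 3 (`O=C(N/N=C/c1cccc(Cl)c1Cl)Nc1ccc(Oc2ccnc3[nH]ccc23)c(F)c1`) stands apart as "not active" (no number reported) with no number reported, so no step from it can be sized. The change to compound 4 (`O=C(N/N=C/c1ccc(Cl)c(Cl)c1)Nc1ccc(Oc2ccnc3[nH]ccc23)c(F)c1`) is 3,4-dichlorophenyl in place of 2,3-dichlorophenyl on a carbon with a double bond to nitrogen and the atoms stay the same. Among the compounds with values here, the only measured step, a 3.9-fold higher number from compound 1 to compound 2 (0.59 log units; beyond the scatter) and made by swapping a different group, is a loose guide: one change moved the number modestly. In this assay a measurable number near those of compound 1 and compound 2 is therefore expected, though another inactive result remains possible. The estimate for compound 4 is 5000 nM with an expected range from 1500 nM to 17000 nM for now.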

Compound 4, half-maximal inhibitory concentration: 14100 nM
Beside the measured number, compound 4's estimate is 2.8-fold (0.45 log units) below it; the range from low to high includes it.
By their numbers in this assay, from the lowest: compound 1; then compounds 2 and 4 (each within the scatter of the next).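

Swapping 2,3-dichlorophenyl for 3,4-dichlorophenyl on the carbon with a double bond to nitrogen gives a measurable number in this assay, although steps from compound 3 cannot be read. Compound 4 stays close to the cyano compound (a 1.6-fold higher number from compound 2 to compound 4 (0.19 log units; within the scatter)) but falls behind the fluoro compound (a 6.1-fold higher number from compound 1 to compound 4 (0.78 log units; beyond the scatter)). No measurement here explains why the two dichlorophenyl isomers differ.

As far as these compounds go, whether a single chlorine would behave like the fluoro or the dichloro compounds remains open. So does the outcome with an amine or a carboxylic acid on this aromatic ring.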